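The source may report more compounds than this note shows. Statements on the series, on what has been measured and on what is new or still open speak of the compounds shown alone.

Compound 1 `C#Cc1cn([C@@H]2O[C@H](CO)[C@@H](O)[C@H]2O)c2ncnc(NC)c12`: in a functional assay on A549 cells (Homo sapiens), read by MTT assay, with a stated time of 72 h (a higher number here means a weaker inhibitor, a lower number a stronger inhibitor), compound 1 gives > 20000 nM, which is a limit of the assay and not a number. Compound 2 `CNc1ncnc2c1c(-c1ccsc1)cn2[C@@H]1O[C@H](CO)[C@@H](O)[C@H]1O`: in this assay compound 2 gives > 20000 nM, again a limit. Compound 3 `C#Cc1cn([C@@H]2O[C@H](CO)[C@@H](O)[C@H]2O)c2ncnc(SC)c12`: in this assay compound 3 gives 140 nM.

Compound 4 `CSc1ncnc2c1c(-c1ccsc1)cn2[C@@H]1O[C@H](CO)[C@@H](O)[C@H]1O` is still to be measured. It is reached from compound 3 by one change, (thiophen-3-yl in place of ethynyl on an aromatic carbon). The same change has been made once already, as thiophen-3-yl in place of ethynyl on an aromatic carbon, and the resulting step is a step that the two limits leave unreadable from compound 1 to compound 2; its size cannot be read because the limit of > 20000 nM in this assay, at which 2 of the 3 values shown sit, covers both values. The two cores differ by methylsulfanyl in place of methylamino on an aromatic carbon, a change that gave an at least 140-fold lower number from compound 1 to compound 3 (2.15 log units; beyond the scatter).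

With no readable earlier step, the expectation for compound 4 rests only on compound 3 at 140 nM, and a step of a 7.1-fold higher number from compound 3 to compound 4 (0.85 log units; beyond the scatter) is expected, toward a weaker inhibitor. Compound 4 is therefore estimated at 1000 nM, between 200 nM and 20000 nM.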

Compound 4, half-maximal inhibitory concentration: > 20000 nM
Compound 4: a limit, no number; the forecaster's own chance of this, stated with the estimate: 30%; middle value at least 20-fold (1.30 log units) away from the limit.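

In this assay, replacing ethynyl with thiophen-3-yl on the methylsulfanyl core gives an at least 140-fold higher number from compound 3 to compound 4 (2.15 log units; beyond the scatter). Compound 4 gives > 20000 nM, which is a limit of the assay and not a number, so only the minimum size of this step is known. As far as these compounds go, the steps from compound 1 to compound 2 and from compound 2 to compound 4 cannot be read, so whether the change acts alike on the two cores stays unknown, because of this limit: the limit of > 20000 nM in this assay, at which 3 of the 4 values shown sit.

Only ethynyl and thiophen-3-yl are shown at this place, so it remains open whether any other group keeps a readable number. A methyl group, a phenyl ring or a longer alkyne such as prop-1-ynyl on the core of compound 3 could help to show this.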